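Methoxy on the benzyl ring of a triazine modulator

The source may hold more compounds than are shown below. What is called first, only, known or untested is meant among the compounds shown, and "the series" means these compounds.

Going by the values given here, compound 1 `Nc1nc(NCc2ccccc2)nc(-c2ccccc2CO)n1` is the only member of this series with a reported number: in a functional assay on cells for positive allosteric modulation of G-protein coupled receptor 68 (Homo sapiens), read by a luciferase reporter and cAMP accumulation, with a stated time of 30 min, at pH 6.8 and pH 8.3, in the presence of a further agent that is not named here (on this read-out higher numbers stand for higher potency (the scale is a negative logarithm) and lower numbers for lower potency), compound 1 gives 4.35, a weak level. Compound 2 `CC(O)c1ccccc1-c1nc(N)nc(NCc2ccccc2)n1`, which carries a hydroxyethyl group in place of the hydroxymethyl, is reported in this assay as "not active" (no number reported), without a number. Compound 3 `COc1ccc(CNc2nc(N)nc(-c3ccccc3CO)n2)cc1` is not yet measured. It differs from compound 1 by methoxy in place of hydrogen on an aromatic carbon. Among the compounds with values here, no measured pair shows this kind of change, so nothing beyond the scatter is expected; the step of a number 0.15 log units higher from compound 1 to compound 3 (within the scatter) is estimated to stay small. Compound 3 is expected to give 4.5, within 3.9 to 5.1.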

Compound 3, negative logarithm of the antagonist equilibrium constant: 3.34
Beside the measured number, compound 3's estimate is 1.16 log units above it, outside the stated range (below it).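

Methoxy in place of hydrogen on this aromatic carbon is not a silent change: in this assay it gives a number 1.01 log units lower from compound 1 to compound 3 (beyond the scatter). Going by these compounds alone, this is the first measured step, and it shows that the read-out responds to substitution at this position, here downward. Nothing at hand accounts for the drop. Going by these compounds, whether fluorine, an amine or a carboxylic acid at the same place would lower the number as well remains open. So does whether methoxy on another carbon of this ring would have the same result.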